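A Chloro Group on Compound 3

The compounds below may be only part of what the source reports. "The series", "measured", "known", "first", "only" and "open" are said of these compounds alone.

In a functional assay on HO8910 cells (Homo sapiens) for inhibition, read by MTT assay, with a stated time of 24 h, tested at 100 ug/mL (a lower number here means less inhibition of growth, a higher number more inhibition of growth at the concentration tested), three related compounds have been tested so far. Compound 1 (`O=C(CCCCC1CCSS1)NO`) is reported as "not active" (no number reported), with no number given. Compound 2 (`O=C(CCCCC(S)CCS)NO`) gives 49.3%. Compound 3 (`O=C(CCCCC1CCSS1)Nc1ccccn1`) gives 51.9%. The values of compound 2 and compound 3 lie within the usual scatter of each other, so these two cannot be told apart on the numbers.

The next compound, compound 4 (`O=C(CCCCC1CCSS1)Nc1ccc(Cl)cn1`), matches compound 3 except at one place: chloro in place of hydrogen on an aromatic carbon. It carries chloro in place of hydrogen on an aromatic carbon of a six-membered aromatic ring with 1 nitrogen, two atoms from the ring nitrogen and para to a large group.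

Among the compounds with values here, no two measured compounds differ at only one place, so the data give no direct measure of what such a swap does. Starting from compound 3 at 51.9%, only a small rise in this assay is expected, one that stays within the scatter. The expected change is a number 3.1 percentage points higher from compound 3 to compound 4 (within the scatter). Within the data shown here, only three compounds stand behind this expectation, so the range is kept wide. For compound 4 the estimated value is 55%, with an expected range from 38% to 72%.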

Compound 4, percent growth inhibition at one concentration: 68.6%
Estimate against measurement, compound 4: 13.6 percentage points below, and the stated range covers the measured number.
By their numbers in this assay, from the lowest: compounds 2 and 3 (each within the scatter of the next); then compound 4.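

In this assay, within the data shown here, this is the first pair of compounds that differ in only one place, so the effect of a single swap can now be read directly: chloro in place of hydrogen on an aromatic carbon, two atoms from the ring nitrogen and para to a large group, gives a number 16.7 percentage points higher from compound 3 to compound 4 (beyond the scatter). The step shows that this ring position accepts a chloro group without loss of growth inhibition. The step also lies beyond the usual scatter of repeated measurements. Nothing measured here speaks to why the swap has this effect, so the result stands as an observation without an explanation.

Going by these compounds, whether the rise is specific to chloro remains open, since a single pair cannot separate it from what bromo, methyl or methoxy might do at the same place. On these data alone, it is also open whether chloro on another carbon of this ring would give a similar step, and whether the same gain would appear at other test concentrations.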